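This account rests on a few compounds, and the source may have more. Where it says the series, first, only, none or still open, it means among the compounds named here.

Compound 1 `CC(C)c1ccccc1-c1nccc(NCc2ccc(-c3cccnc3)cc2)n1`: 150 nM
Compound 2 `Cc1cnc(-c2ccccc2C(C)C)nc1NCc1ccc(-c2cccnc2)cc1`: 70 nM
Compound 3 `CC(C)c1ccccc1-c1ncc(F)c(NCc2ccc(-c3cccnc3)cc2)n1`: 110 nM

These three compounds were measured in an assay on a protein complex for inhibition of ubiquitin carboxyl-terminal hydrolase 1/WD repeat-containing protein 48 (Homo sapiens), read by fluorescence; a higher number here means a weaker inhibitor, a lower number a stronger inhibitor. The cores of compound 1 and compound 2 differ by methyl in place of hydrogen on an aromatic carbon, a change that gave a 2.1-fold lower number from compound 1 to compound 2 (0.33 log units; beyond the scatter). Compound 3 differs from compound 1 by fluoro in place of hydrogen on an aromatic carbon, and that change gave a 1.4-fold lower number from compound 1 to compound 3 (0.13 log units; within the scatter). Compound 4 `Cc1cnc(-c2ccccc2C(C)C)nc1NCc1ccc(-c2ccc(F)nc2)cc1`, not yet measured, carries the same kind of change relative to compound 2: fluoro in place of hydrogen on an aromatic carbon. The surroundings are not identical: in compound 3 the fluoro sits on a six-membered aromatic ring with 2 nitrogen, two atoms from the ring nitrogen and para to a 2-isopropylphenyl group, whereas in compound 4 it sits on a six-membered aromatic ring with 1 nitrogen, next to the ring nitrogen and para to a large group. Because a 1.4-fold lower number from compound 1 to compound 3 (0.13 log units; within the scatter) stayed within the scatter, a step of similar size is expected in this assay, namely a 1.2-fold lower number from compound 2 to compound 4 (0.07 log units; within the scatter). Compound 4 is therefore estimated at 60 nM, expected to lie between 30 nM and 130 nM.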

Compound 4, half-maximal inhibitory concentration: 80 nM
For compound 4 the middle estimate is 1.3-fold (0.12 log units) below the measured one; the measured number falls inside the stated range.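

The pyridin-3-yl to 6-fluoropyridin-3-yl change gave a 1.1-fold higher number from compound 2 to compound 4 (0.06 log units; within the scatter) in this assay. Set beside the earlier fluoro step, the two results cannot be told apart: the same change on two cores in this assay, a 1.4-fold lower number (0.13 log units; within the scatter) from compound 1 to compound 3 and a 1.1-fold higher number (0.06 log units; within the scatter) from compound 2 to compound 4, 1.6-fold (0.19 log units) apart, within the scatter of two such steps. Within the data shown here, this shows that fluoro in place of hydrogen produced no step beyond the scatter on either core, but it does not show that a fixed effect carries from one core to another, since the fluoro sits on a different ring in each pair and only two pairs are available.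

The compounds shown leave open whether an amine, a methoxy group or a nitrile in place of this fluoro would produce a step beyond the scatter. They also leave open how the pyridin-3-yl to 6-fluoropyridin-3-yl change would behave on the core of compound 1.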